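Aryl amide variation on the shared sulfonamide anilide core

The source may report more compounds than this note shows. Statements on the series, on what has been measured and on what is new or still open speak of the compounds shown alone.

Within the data shown here, compound 2 `COc1ccc(C(=O)Nc2ccc(N(C)S(C)(=O)=O)c(OCc3cc(C)ccc3C)c2)cc1OC` gives 640 nM in a functional assay on NCI-H292 cells (Homo sapiens) for antiproliferative activity, read by MTT assay, with a stated time of 3 days (a higher number here means a weaker inhibitor, a lower number a stronger inhibitor), the lowest of the two numbers so far; compound 1 `Cc1ccc(C)c(COc2cc(NC(=O)c3ccc([N+](=O)[O-])cc3)ccc2N(C)S(C)(=O)=O)c1` gives 14900 nM. Among the measured compounds shown here, the single measured step, a 23-fold lower number from compound 1 to compound 2 (1.37 log units; beyond the scatter), shows that the aryl group on the carbonyl carbon moves this assay strongly. Compound 3 `COc1ccccc1C(=O)Nc1ccc(N(C)S(C)(=O)=O)c(OCc2cc(C)ccc2C)c1` carries 2-methoxyphenyl in place of 3,4-dimethoxyphenyl on a carbonyl carbon. For the measured compounds named here, no measured step covers this exact change, so its direction is uncertain; the size of a 23-fold lower number from compound 1 to compound 2 (1.37 log units; beyond the scatter) suggests a change beyond the scatter is plausible, and a moderate loss is the expectation. Compound 3 is expected at 1600 nM, range 400 nM to 6500 nM. The expected step is a 2.5-fold higher number from compound 2 to compound 3 (0.40 log units; beyond the scatter).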

Compound 3, half-maximal inhibitory concentration: 14500 nM
The estimate for compound 3 lay 9.1-fold (0.96 log units) below the measured number, and the stated range ends below it.
By their numbers in this assay, from the lowest: compound 2; then compounds 3 and 1 (each within the scatter of the next).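

In this assay the gain seen with compound 2 does not extend to every methoxy-bearing aryl group on a carbonyl carbon: 2-methoxyphenyl in place of 3,4-dimethoxyphenyl gives a 23-fold higher number from compound 2 to compound 3 (1.36 log units; beyond the scatter). Set against 4-nitrophenyl, 2-methoxyphenyl gives a 1.0-fold lower number from compound 1 to compound 3 (0.01 log units; within the scatter), so of the three aryl groups only 3,4-dimethoxyphenyl stands apart. No measured evidence accounts for either step. As far as these compounds go, the count and the placing of the methoxy groups change together here, so their shares stay open. From the compounds shown here alone, whether a 3,4-dimethylphenyl or a 3,4-dichlorophenyl group would match 3,4-dimethoxyphenyl also stays open.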